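The source may hold more compounds than are shown below. What is called first, only, known or untested is meant among the compounds shown, and "the series" means these compounds.

Measured compounds:
Compound 1, `CCCCC[C@@H](C(=O)NCNC(=O)c1ccc(-c2ccc(C(=O)O)c(OCC)c2)o1)[C@@H](CC)N(O)C=O`: in an assay on CHO cells for inhibition of bone morphogenetic protein 1 (Homo sapiens), with stated times of 10 min and 60 min (on this read-out higher numbers stand for weaker inhibition and lower numbers for stronger inhibition), it gives a limit, < 1 nM.
Compound 2, `CCCCC[C@H](CN(O)C=O)C(=O)NCNC(=O)c1ccc(-c2ccccc2)o1`: in this assay compound 2 gives 25 nM.

Going by the values given here, compound 2 stands as the only compound with a plain number in this assay. The other value shown, that of compound 1, is a limit of the assay, (the limit of < 1 nM in this assay, at which 1 of the 2 values shown sits), so the two cannot be set in order against each other. Compound 3, `CCCCC[C@@H](C(=O)NCNC(=O)c1ccc(-c2ccccc2)o1)[C@@H](CC)N(O)C=O`, differs from compound 2 by ethyl in place of hydrogen on a saturated chain carbon bound to an amide-type nitrogen and a saturated chain carbon. Among the compounds with values here, no step between two measured compounds covers this change, so its size has to be expected rather than read off. The account expects the step from compound 2 to compound 3 to give stronger inhibition in this assay, beyond the usual scatter, estimated as an 8.3-fold lower number from compound 2 to compound 3 (0.92 log units; beyond the scatter). Compound 3 is accordingly estimated at 3 nM in this assay, within a range from 0.8 nM to 12 nM, and it is expected that the assay may report only a limit for it.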

Compound 3, half-maximal inhibitory concentration: 32 nM
The estimate for compound 3 lay 11-fold (1.03 log units) below the measured number; measured number outside the range, above it.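

In this assay ethyl in place of hydrogen on a saturated chain carbon bound to an amide-type nitrogen and a saturated chain carbon gives a 1.3-fold higher number from compound 2 to compound 3 (0.11 log units; within the scatter) and so, on its own, does not set compound 3 apart from compound 2. Compounds 1 and 3 both carry this ethyl, and the group of 12 heavy atoms on the aromatic carbon of compound 1, in place of the group of 6 heavy atoms in compound 3, goes with an at least 32-fold higher number from compound 1 to compound 3 (1.50 log units; beyond the scatter) as the large step in this set. Compound 1 stands at a limit of the assay: the limit of < 1 nM in this assay, at which 1 of the 3 values shown sits.

As far as these compounds go, it remains open whether a propyl group or a longer chain on the same carbon would read any differently from ethyl. From the compounds shown here alone, it also remains open which part of the group of 12 heavy atoms carries the large step, and whether an amine on the aromatic ring would do the same.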